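Fluorine on the benzyl group: compound 3 to compound 4

The source may hold more compounds than are shown below. What is called first, only, known or untested is meant among the compounds shown, and "the series" means these compounds.

Compound 1, `COc1ccc(N(Cc2ccc(F)cc2)NC(=O)NCCCN2CCN(c3ccccc3OC)CC2)cc1`, in an assay on CHO cells for displacement of a labelled ligand from D(4) dopamine receptor (Homo sapiens), read by radioligand binding (on this read-out lower numbers stand for stronger inhibition and higher numbers for weaker inhibition), gives 2.9 nM.
Compound 2, `O=C(NCCCN1CCN(c2ccc(Br)cc2)CC1)NN(Cc1ccccc1)c1ccccc1`, in this assay gives 14 nM.
Compound 3, `O=C(NCCCN1CCN(c2ncccn2)CC1)NN(Cc1ccccc1)c1ccccc1`, in this assay gives 18 nM.

Compound 3 has the highest of the three numbers. Its nearest neighbour is compound 2, and the step of a 1.3-fold higher number from compound 2 to compound 3 (0.11 log units; within the scatter) lies within the scatter. Compound 1 stands furthest away, with a number well beyond the scatter below that of compound 3; compound 1 differs from compound 3 in several places at once, so its two values show no single change.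

Compound 4, `O=C(NCCCN1CCN(c2ncccn2)CC1)NN(Cc1ccc(F)cc1)c1ccccc1`, arises from compound 3 by one change: fluoro in place of hydrogen on an aromatic carbon. For the measured compounds named here, no measured pair isolates this change; the only step at hand, from compound 2 to compound 3, concerns a different part of the molecule. Compound 1 carries the same 4-fluorobenzyl group, but its other differences prevent a clean reading. The expectation for compound 4 in this assay is therefore a step of a 1.3-fold lower number from compound 3 to compound 4 (0.11 log units; within the scatter), not beyond the scatter. Compound 4 is estimated at 14 nM, with a range from 6 nM to 35 nM.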

Compound 4, inhibition constant: 19 nM
Compound 4: middle estimate off by 1.4-fold (0.13 log units), on the low side; the measured number falls inside the stated range.
By their numbers in this assay, from the lowest: compound 1; then compounds 2, 3 and 4 (each within the scatter of the next).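

In this assay, for the compounds shown here, the change from benzyl to 4-fluorobenzyl can now be read on its own for the first time (a 1.1-fold higher number from compound 3 to compound 4 (0.02 log units; within the scatter)). At this place, para to a large group on a six-membered aromatic ring of carbon only, fluoro in place of hydrogen stays within the scatter on a core carrying the pyrimidin-2-yl group, something compound 1 could not show, as its 4-fluorobenzyl group comes with other differences. Nothing available explains this outcome.

Open, going by these compounds, is whether chloro, trifluoromethyl or a carboxylic acid at this same place would also stay within the scatter of compound 3. Also open, on these data alone, is whether fluoro at this place would give a similar reading on the core of compound 2, which carries 4-bromophenyl instead of pyrimidin-2-yl.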